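Replacing the nitrophenyl arm of compound 3 with phenylsulfonyl

The source may report more compounds than this note shows. Statements on the series, on what has been measured and on what is new or still open speak of the compounds shown alone.

Measured compounds:
compound 1 `CCOC(=O)c1cnc(C(C)(C)C)nc1NN1C(=O)C=C(C)C1=O` gives 1000 nM
compound 2 `CCOC(=O)c1cnc(-c2cccc(Br)c2)nc1NN1C(=O)C=C(C)C1=O` gives 700 nM
compound 3 `CCOC(=O)c1cnc(-c2cccc([N+](=O)[O-])c2)nc1NN1C(=O)C=C(C)C1=O` gives 7000 nM

All three were tested in a functional assay on Jurkat cells for inhibition of nuclear factor NF-kappa-B complex (Homo sapiens); a lower number here means a stronger inhibitor, a higher number a weaker inhibitor. Compound 3 stands as the highest number of the three: the nearest is compound 1, with a 7.0-fold higher number from compound 1 to compound 3 (0.85 log units; beyond the scatter), and the furthest is compound 2, with a 10-fold higher number from compound 2 to compound 3 (1.00 log units; beyond the scatter). The step from compound 1 to compound 2, a 1.4-fold lower number from compound 1 to compound 2 (0.15 log units; within the scatter), is within the scatter, so those two cannot be ranked against each other.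

Compound 4 `CCOC(=O)c1cnc(S(=O)(=O)c2ccccc2)nc1NN1C(=O)C=C(C)C1=O` differs from compound 3 in one place: phenylsulfonyl in place of 3-nitrophenyl on an aromatic carbon. Within the data shown here, no measured step exchanges a group for phenylsulfonyl, so the two steps that bear on it are only those that lead into compound 3, both of which rise to it. They show that the 3-nitrophenyl arm of compound 3 goes with the weakest number measured, and any replacement has room to move back toward compound 1 and compound 2, but the data give no direct anchor for phenylsulfonyl itself.

Compound 4 is therefore expected to give 2500 nM in this assay, in the range 600 nM to 10000 nM, a step of a 2.8-fold lower number from compound 3 to compound 4 (0.45 log units; beyond the scatter) that is estimated to be modestly downward, with the wide range reflecting the lack of any measured phenylsulfonyl analog.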

Compound 4, half-maximal inhibitory concentration: 10000 nM
Compound 4: middle estimate off by 4.0-fold (0.60 log units), on the low side, within the range that was stated.
By their numbers in this assay, from the lowest: compounds 2 and 1 (each within the scatter of the next); then compounds 3 and 4 (each within the scatter of the next).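

In this assay, exchanging 3-nitrophenyl for phenylsulfonyl gives a 1.4-fold higher number from compound 3 to compound 4 (0.15 log units; within the scatter), so these two groups cannot be told apart at this position. Both other groups differ clearly from phenylsulfonyl: the exchange from 3-bromophenyl gives a 14-fold higher number from compound 2 to compound 4 (1.15 log units; beyond the scatter), and the exchange from tert-butyl gives a 10-fold higher number from compound 1 to compound 4 (1.00 log units; beyond the scatter). Compounds 3 and 4 thus form a weaker pair, and having a six-membered aromatic ring in the group does not by itself decide the outcome, as compound 2 carries such a ring yet groups with compound 1, whose tert-butyl has none.

Nothing measured here gives a reason for this split. From the compounds shown here alone, it remains open whether an unsubstituted phenyl, an amine or methylsulfonyl at this position would fall with compounds 1 and 2 or with compounds 3 and 4.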